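A few compounds are considered here, and "the series" means these few. Any claim that something is new, unique, unknown or untested is made for them only; others in the source may bear on it.

Compound 1 `CC(C)C[C@H](NC(=O)OC(C)(C)C)C(=O)N1CCC[C@H](C(=O)N2[C@H](C(=O)O)[C@H]2C(=O)O)C1`: "not determined" (no result reported)
Compound 2 `CC(C)C[C@@H](NC(=O)OC(C)(C)C)C(=O)N1CCC[C@H]1C(=O)N1[C@H](C(=O)OCc2ccccc2)[C@H]1C(=O)OCc1ccccc1`: > 100000 nM

In a functional assay on J774 cells (Mus musculus) for cytotoxicity, with a stated time of 48 h (on this read-out higher numbers stand for weaker inhibition and lower numbers for stronger inhibition), compound 2 gives > 100000 nM, which is a limit of the assay and not a number. Among the compounds with values here, compound 1 has no reported result, so compound 2 offers the only reading, and it fixes no exact position.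

Compound 3 `CC(C)C[C@@H](NC(=O)OC(C)(C)C)C(=O)N1CCC[C@@H]1C(=O)N1[C@H](C(=O)OCc2ccccc2)[C@H]1C(=O)OCc1ccccc1` is the next compound to be measured. The change is the two compounds have the same atoms and bonds and differ only in configuration as drawn: 1 of 4 stereo elements differ; a stereocentre at a saturated ring carbon is drawn S in compound 2 and R in compound 3. Within the data shown here, nothing leaves or enters, and only that one saturated ring carbon is drawn differently.

Among the measured compounds shown here, the expectation rests on compound 2 and its limit of > 100000 nM, with no measured step to guide it. The estimated step, a number no higher from compound 2 to compound 3 (the limit leaves the size open), is expected to stay within the usual scatter, with no direction favoured. For compound 3 the expected value in this assay is 100000 nM, with an estimated range from 40000 nM to 200000 nM.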

Compound 3, half-maximal inhibitory concentration: > 100000 nM
Compound 3 gave a limit, no number; the forecaster's own chance of this, stated with the estimate: 80%; the middle value sits exactly at the limit.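

In this assay, within the data shown here, compound 2 and compound 3 each return only a limit of the assay, and no step between them can be read. The compounds shown leave open whether the drawn configuration at that saturated ring carbon affects cytotoxicity at all.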